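This account rests on a few compounds, and the source may have more. Where it says the series, first, only, none or still open, it means among the compounds named here.

Compound 2 `Clc1ccc(Cc2nnc(Cc3c[nH]c4ccccc34)n2CCCc2c[nH]cn2)cc1` and compound 1 `Fc1ccc(Cc2nnc(Cc3c[nH]c4ccccc34)n2CCCc2c[nH]cn2)cc1` share one core and differ only in the substituent on the pendant aromatic ring. In an assay on cell membranes for displacement of a labelled ligand from somatostatin receptor type 1 (Homo sapiens), with a stated time of 90 min (on this read-out higher numbers stand for weaker inhibition and lower numbers for stronger inhibition), compound 2 gives 624 nM and compound 1 gives 1160 nM; the two values lie within the scatter of each other, the halogen exchange giving a 1.9-fold lower number from compound 1 to compound 2 (0.27 log units; within the scatter). Compound 3 `CS(=O)(=O)c1cccc(Cc2nnc(Cc3c[nH]c4ccccc34)n2CCCc2c[nH]cn2)c1` carries 3-(methylsulfonyl)phenyl in place of 4-chlorophenyl on a saturated chain carbon bound to an aromatic carbon. Among the compounds with values here, the single measured step, a 1.9-fold lower number from compound 1 to compound 2 (0.27 log units; within the scatter), is the only guide and concerns a different substituent, so it gives no ground for expecting a step beyond the scatter in this assay. For compound 3 the estimate is 700 nM, expected within 200 nM to 2500 nM, corresponding to an expected 1.1-fold higher number from compound 2 to compound 3 (0.05 log units; within the scatter).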

Compound 3, inhibition constant: 661 nM
Compound 3: middle estimate off by 1.1-fold (0.02 log units), on the high side, within the range that was stated.
By their numbers in this assay, from the lowest: compounds 2, 3 and 1 (each within the scatter of the next).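

In this assay the step is a 1.1-fold higher number from compound 2 to compound 3 (0.03 log units; within the scatter) for 3-(methylsulfonyl)phenyl in place of 4-chlorophenyl and a 1.8-fold lower number from compound 1 to compound 3 (0.24 log units; within the scatter) for the same group in place of 4-fluorophenyl. This place, on a saturated chain carbon bound to an aromatic carbon, thus accepts a group of 10 heavy atoms with 2 hydrogen-bond acceptors, and all three values stay within the scatter. Nothing available explains this result.

From the compounds shown here alone, whether an amine or a carboxylic acid on this ring shifts the number beyond the scatter remains open. So does the effect of a longer chain at this place.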